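The source may report more compounds than this note shows. Statements on the series, on what has been measured and on what is new or still open speak of the compounds shown alone.

Measured in an ADME assay (liver) for metabolic stability, with Liver microsome (Rattus norvegicus) as the target, using microsomes and NADPH, with a stated time of 30 min, tested at 1 uM (a lower number here means slower removal, a higher number faster removal of the compound), so far
- compound 1 `Nc1ccc(S(=O)(=O)N2CCN(c3ncc(C(O)(C(F)(F)F)C(F)(F)F)cc3C3CC3)CC2)cn1` gives 27 mL.min-1.g-1 here
- compound 2 `COCC#Cc1cc(C(O)(C(F)(F)F)C(F)(F)F)cnc1N1CCN(S(=O)(=O)c2ccc(N)nc2)CC1` gives 399 mL.min-1.g-1 here

Compound 2 holds the higher of the two values. Compound 3 `Nc1ccc(S(=O)(=O)N2CCN(c3ncc(C(O)(C(F)(F)F)C(F)(F)F)cc3C#CCCO)CC2)cn1` differs from it by hydroxymethyl in place of methoxy on a saturated chain carbon bound to a triple-bonded carbon in a swap of hydroxymethyl in place of methoxy. Among the measured compounds shown here, the one measured step of a 15-fold higher number from compound 1 to compound 2 (1.17 log units; beyond the scatter) is large and beyond the scatter, but it replaces cyclopropyl with 3-methoxyprop-1-yn-1-yl, so no measured pair holds this swap. With compound 2 at 399 mL.min-1.g-1 as the high end, a partial move downward is expected. The expected step is a 2.7-fold lower number from compound 2 to compound 3 (0.42 log units; beyond the scatter) on this thin evidence. Compound 3 is estimated at 150 mL.min-1.g-1 with an expected range of 40 mL.min-1.g-1 to 400 mL.min-1.g-1 for now.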

Compound 3, intrinsic clearance in microsomes: 68 mL.min-1.g-1
The estimate for compound 3 lay 2.2-fold (0.34 log units) above the measured number, within the range that was stated.
By their numbers in this assay, from the lowest: compound 1; then compound 3; then compound 2.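

In this assay the change on the saturated chain carbon bound to a triple-bonded carbon separates the end of the chain from the alkyne itself: hydroxymethyl in place of methoxy brings the number down (a 5.9-fold lower number from compound 2 to compound 3 (0.77 log units; beyond the scatter)). Against cyclopropyl on an aromatic carbon, 4-hydroxybut-1-yn-1-yl keeps only part of the earlier rise (a 2.5-fold higher number from compound 1 to compound 3 (0.40 log units; beyond the scatter)). No evidence on the cause of either step is available.
Open, going by these compounds, is whether an amine, a carboxylic acid or a longer chain in place of hydroxymethyl would bring the number closer to that of compound 1.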